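The compounds below may be only part of what the source reports. "The series", "measured", "known", "first", "only" and "open" are said of these compounds alone.

In a functional assay on CHO cells for antagonist activity at metabotropic glutamate receptor 5 (Rattus norvegicus), read by FLIPR and calcium flux (on this read-out higher numbers stand for weaker inhibition and lower numbers for stronger inhibition), compound 3 `Cc1ccc2cnc(-c3cccc(S(C)(=O)=O)c3)nc2n1` gives > 30000 nM, which is a limit of the assay and not a number. Compound 1 `COc1ccccc1-c1ncc2ccc(C)nc2n1` likewise gives > 30000 nM, again a limit. Within the data shown here, compound 2 `Cc1ccc2cnc(-c3cccc(C#N)c3)nc2n1` gives 240 nM, the only number among the three. Among the measured compounds shown here, the one measured step, an at least 120-fold higher number from compound 2 to compound 3 (2.09 log units; beyond the scatter), with methylsulfonyl in place of cyano, ends at the limit of > 30000 nM in this assay, at which 2 of the 3 values shown sit. Compound 4 `Cc1cccc(-c2ncc3ccc(C)nc3n2)c1` differs from compound 3 by methyl in place of methylsulfonyl on an aromatic carbon. No measured step bears directly on methyl, but the reverse of the shown step suggests that leaving methylsulfonyl can go with a large fall in this assay, because compound 2 gives 240 nM. A large fall is therefore expected for compound 4, its size uncertain. Compound 4 is estimated at 600 nM, between 100 nM and 6000 nM. That estimate means an expected step of an at least 50-fold lower number from compound 3 to compound 4 (1.69 log units; beyond the scatter).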

Compound 4, half-maximal inhibitory concentration: 53 nM
Compound 4: the middle estimate sits 11-fold (1.05 log units) above what was measured; the measured number lies below the stated range.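

Methyl, with 0 hydrogen-bond acceptors, suits this aromatic carbon better than either group seen there before in this assay: the change gives an at least 560-fold lower number from compound 3 to compound 4 (2.75 log units; beyond the scatter), and even against the nitrile it gives a 4.5-fold lower number from compound 2 to compound 4 (0.66 log units; beyond the scatter). So the nitrile of compound 2 is not needed for inhibition at this place. The first of these steps starts from a limit of the assay, the value of compound 3: the limit of > 30000 nM in this assay, at which 2 of the 4 values shown sit.

The compounds shown leave open whether ethyl, chlorine or an amine on this carbon would match methyl. They also leave open how methyl would fare elsewhere on this ring.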